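Swapping one group on compound 2

A few compounds are considered here, and "the series" means these few. Any claim that something is new, unique, unknown or untested is made for them only; others in the source may bear on it.

Compound 1 `FC(F)(F)c1nccc(N[C@H]2CC[C@@H](Nc3ccncn3)CC2)n1`: 1.9
Compound 2 `CSc1nnc2ccc(N[C@H]3CC[C@@H](Nc4ccnc(C(F)(F)F)n4)CC3)nn12`: 2.8

In a physicochemical assay for lipophilicity, read by LC-MS (on this read-out higher numbers stand for higher lipophilicity and lower numbers for lower lipophilicity), compound 2 gives 2.8, the higher of the two numbers, and its gap to compound 1 at 1.9 lies beyond the usual scatter. Compound 3 `FC(F)(F)c1nccc(N[C@H]2CC[C@@H](Nc3ccc4nnc(C(F)(F)F)n4n3)CC2)n1` carries trifluoromethyl in place of methylsulfanyl on an aromatic carbon. Among the compounds with values here, the two measured compounds differ in more than one place, so no measured step guides this swap. The expected change is a number 0.10 log units higher from compound 2 to compound 3 (within the scatter), slightly upward and not beyond the scatter. Compound 3 is estimated at 2.9, with an expected range from 2.4 to 3.4.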

Compound 3, distribution coefficient: 3.8
Beside the measured number, compound 3's estimate is 0.90 log units below it; the whole stated range lies below it.
By their numbers in this assay, from the lowest: compound 1; then compound 2; then compound 3.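

Within the data shown here, at this aromatic carbon of the five-membered ring, trifluoromethyl in place of methylsulfanyl gives a number 1.00 log units higher from compound 2 to compound 3 (beyond the scatter) in this assay and provides the first measured single-place change. It shows that the group on this carbon can, on its own, move the number beyond the usual scatter. No measurement shown here explains the size of this step.

From the compounds shown here alone, whether a methyl group, a methoxy group or an amine on this same carbon would land nearer compound 2 or compound 3 remains open. So does whether this swap would give a similar step on another core.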